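The source may report more compounds than this note shows. Statements on the series, on what has been measured and on what is new or still open speak of the compounds shown alone.

Measured compounds:
compound 1 `Cc1nc(C(NC(=O)C(=O)Nc2ccc(Cl)cc2)C2CCNCC2)sc1CCO` — 85400 nM
compound 2 `Cc1nc(C(NC(=O)C(=O)Nc2ccc(C(F)(F)F)cc2)C2CCCCN2)sc1CO` — > 75500 nM

For the measured compounds named here, in an ADME assay on TZM-b1 cells (Homo sapiens) for cytotoxicity, read by XTT assay, with a stated time of 3 days (a lower number here means that less compound is tolerated, a higher number that more compound is tolerated), compound 1 gives 85400 nM, the only number in hand. Compound 2 gives in this assay only > 75500 nM, a limit of the assay rather than a number; the limit of > 75500 nM in this assay, at which 1 of the 2 values shown sits, describes that limit. Compound 3 `Cc1nc(C(NC(=O)C(=O)Nc2ccc(Cl)cc2)C2CCCCN2)sc1CCO` differs from compound 1 by piperidin-2-yl in place of piperidin-4-yl on a saturated chain carbon bound to an amide-type nitrogen and an aromatic carbon. Going by the values given here, no step between measured compounds differing in one place is available, so the size of this change in this assay is expected to be none beyond the scatter. Compound 3 is therefore estimated at 85000 nM, between 40000 nM and 150000 nM. The expected step is a 1.0-fold lower number from compound 1 to compound 3 (0.00 log units; within the scatter).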

Compound 3, half-maximal cytotoxic concentration: 32800 nM
For compound 3 the middle estimate is 2.6-fold (0.41 log units) above the measured one, and the stated range ends above it.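

In this assay piperidin-2-yl in place of piperidin-4-yl on a saturated chain carbon bound to an amide-type nitrogen and an aromatic carbon brings a 2.6-fold lower number from compound 1 to compound 3 (0.42 log units; beyond the scatter) and the two compounds hold the same atoms, joined differently. For the compounds shown here, this is the first sign that the point of attachment of this ring, and not only its presence, bears on how much compound the cells tolerate. Nothing at hand accounts for this step.

The compounds shown leave open where piperidin-3-yl or an open-chain amine would fall on this carbon. They also leave open whether the step holds with trifluoromethyl in place of the chlorine.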